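Adding a Methyl Group to a Fused Ring: Expected Clearance

The source may hold more compounds than are shown below. What is called first, only, known or untested is meant among the compounds shown, and "the series" means these compounds.

Measured compounds:
Compound 1, `Nc1ccc(S(=O)(=O)N2CCN(c3ncc(C(O)(C(F)(F)F)C(F)(F)F)cc3-c3cccnc3)CC2)cn1`: 20 mL.min-1.g-1
Compound 2, `Cc1ccc(-c2cc(C(O)(C(F)(F)F)C(F)(F)F)cnc2N2CCN(S(=O)(=O)c3ccc(N)nc3)CC2)cn1`: 182 mL.min-1.g-1
Compound 3, `Nc1ccc(S(=O)(=O)N2CCN(c3ncc(C(O)(C(F)(F)F)C(F)(F)F)cc3-c3ccc4ocnc4c3)CC2)cn1`: 120 mL.min-1.g-1

All three compounds share a core and were tested in an ADME assay (liver) for metabolic stability, with Liver microsome (Rattus norvegicus) as the target, using microsomes and NADPH, with a stated time of 30 min, tested at 1 uM; on this read-out higher numbers stand for fast clearance and lower numbers for slow clearance. Compound 1 gives 20 mL.min-1.g-1. Compound 2 differs from compound 1 by methyl in place of hydrogen on an aromatic carbon, and this gives a 9.1-fold higher number from compound 1 to compound 2 (0.96 log units; beyond the scatter). Compound 3 carries a different ring at one position; the difference from compound 1 is 1,3-benzoxazol-5-yl in place of pyridin-3-yl on an aromatic carbon, and here a 6.0-fold higher number from compound 1 to compound 3 (0.78 log units; beyond the scatter) is seen. Compound 2 and compound 3 lie close to each other, with a 1.5-fold lower number from compound 2 to compound 3 (0.18 log units; within the scatter).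

Compound 4, `Cc1nc2cc(-c3cc(C(O)(C(F)(F)F)C(F)(F)F)cnc3N3CCN(S(=O)(=O)c4ccc(N)nc4)CC3)ccc2o1`, has not yet been tested in this assay. It differs from compound 3 by methyl in place of hydrogen on an aromatic carbon. Within the data shown here, this is the same kind of change as the one from compound 1 to compound 2, but the surroundings differ: in compound 2 the methyl enters on a six-membered aromatic ring with 1 nitrogen, next to the ring nitrogen and para to a large group, whereas in compound 4 it enters on a five-membered aromatic ring with 1 nitrogen and 1 oxygen, part of a fused system of two rings, next to the ring nitrogen and next to the ring oxygen.

Because a 9.1-fold higher number from compound 1 to compound 2 (0.96 log units; beyond the scatter) was seen for the earlier methyl, a step of similar direction is expected, though smaller since the new place is not the same, giving an estimated 1.8-fold higher number from compound 3 to compound 4 (0.26 log units; within the scatter). Compound 4 is therefore expected to give about 220 mL.min-1.g-1, likely between 90 mL.min-1.g-1 and 450 mL.min-1.g-1.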

Compound 4, intrinsic clearance in microsomes: 99 mL.min-1.g-1
Beside the measured number, compound 4's estimate is 2.2-fold (0.35 log units) above it; the measured number falls inside the stated range.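

In this assay, putting a methyl on the five-membered aromatic ring gives a 1.2-fold lower number from compound 3 to compound 4 (0.08 log units; within the scatter), so on this core the change cannot be told apart from no change at all. The same swap of hydrogen for methyl therefore did not carry over from one core to the other with the same size, and the gap between the two results is real rather than noise: the same change on two cores in this assay, a 9.1-fold higher number (0.96 log units; beyond the scatter) from compound 1 to compound 2 and a 1.2-fold lower number (0.08 log units; within the scatter) from compound 3 to compound 4, 11-fold (1.04 log units) apart, beyond the scatter of two such steps The other new comparisons place the result as a 1.8-fold lower number from compound 2 to compound 4 (0.26 log units; within the scatter) and a 5.0-fold higher number from compound 1 to compound 4 (0.69 log units; beyond the scatter), but the two methyl groups sit on different rings, and two pairs alone cannot say which feature of the surroundings decides the outcome, nor do they set a rule for any other core.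

As far as these compounds go, it remains open whether a different group on the same carbon of the five-membered aromatic ring, such as an ethyl, a methoxy or an amine, would also leave the clearance where compound 3 has it. Also open, from the compounds shown here alone, is whether a methyl placed elsewhere on the 1,3-benzoxazol-5-yl ring would behave like the methyl of compound 4 or like the much larger step seen with compound 2.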